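This account rests on a few compounds, and the source may have more. Where it says the series, first, only, none or still open, it means among the compounds named here.

Measured compounds:
- Compound 1 `O=C(Nc1cccc(C(F)(F)F)c1)N[C@H]1CC[C@H](Oc2cccc(C(F)(F)F)c2)CC1`, 4900 nM
- Compound 2 `O=C(Nc1cccc(C(F)(F)F)c1)N[C@H]1CC[C@@H](Oc2ccc(F)cc2)CC1`, 10400 nM
- Compound 3 `O=C(Nc1cccc(C(F)(F)F)c1)N[C@H]1CC[C@H](Oc2cccc(F)c2)CC1`, 29900 nM

All three were tested in a functional assay on CRL2813 cells (Homo sapiens) for antiproliferative activity, read by sulforhodamine B assay, with a stated time of 3 days, in the presence of a further agent that is not named here; on this read-out lower numbers stand for stronger inhibition and higher numbers for weaker inhibition. On the numbers shown, compound 1 stands lowest of the three, so it is the strongest inhibitor here; compound 2 is nearest to it, and compound 3 is furthest away. Within the data shown here, the one measured step that bears on the new compound is a 6.1-fold higher number from compound 1 to compound 3 (0.79 log units; beyond the scatter), where a smaller fluorine-bearing ring took the place of the trifluoromethyl-bearing one and the number rose. Compound 2 carries its fluorine at a different spot and also sits higher than compound 1.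

Compound 4 `O=C(Nc1cccc(C(F)(F)F)c1)N[C@H]1CC[C@H](Oc2ccccc2F)CC1` has not been measured. It differs from compound 1 by 2-fluorophenyl in place of 3-(trifluoromethyl)phenyl on an oxygen on a saturated carbon. Given that the two measured swaps toward a fluorophenyl both weakened inhibition, a similar rise is expected here, expressed as a 3.1-fold higher number from compound 1 to compound 4 (0.49 log units; beyond the scatter). The estimated value of compound 4 in this assay is therefore 15000 nM, with an expected range from 5000 nM to 45000 nM.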

Compound 4, half-maximal inhibitory concentration: 21900 nM
For compound 4 the middle estimate is 1.5-fold (0.16 log units) below the measured one; low and high end bracket the measured number.
By their numbers in this assay, from the lowest: compound 1; then compound 2; then compounds 4 and 3 (each within the scatter of the next).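

In this assay, 2-fluorophenyl in place of 3-(trifluoromethyl)phenyl on the oxygen gives a 4.5-fold higher number from compound 1 to compound 4 (0.65 log units; beyond the scatter) as a second measured step, so this is no longer a single observation: both fluorophenyl rings tied to the same core in this way give higher numbers than the 3-(trifluoromethyl)phenyl ring of compound 1. The new information is the change of 3-fluorophenyl to 2-fluorophenyl, which gives a 1.4-fold lower number from compound 3 to compound 4 (0.14 log units; within the scatter) and shows that, on these numbers, the two fluorine placements cannot be told apart. Nothing available here explains why the ring of compound 1 gives the lower number.

The compounds shown leave open whether the gain belongs to trifluoromethyl itself or to any larger group, such as a chlorine atom, a methoxy group or a tert-butyl group, at that place on the ring. They also leave open how a plain phenyl ring, or a ring carrying an amine or a carboxylic acid, would behave on this oxygen.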